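A few compounds are considered here, and "the series" means these few. Any claim that something is new, unique, unknown or untested is made for them only; others in the source may bear on it.

Compound 1 `COc1cc(/C=C/C(=O)/C=C/c2cc(OC)c(OC)c(OC)c2)ccc1OCc1cn(CCOc2cc(=O)oc3ccccc23)nn1`: 99%
Compound 2 `COc1cc(/C=C/C(=O)/C=C/c2ccco2)ccc1OCc1cn(CCOc2cc(=O)oc3ccccc23)nn1`: 78%

Within the data shown here, in a functional assay on THP-1 cells (Homo sapiens) for inhibition, read by sulforhodamine B assay, with a stated time of 48 h, tested at 50 uM (a higher number here means more inhibition of growth at the concentration tested, a lower number less inhibition of growth), compound 2 gives 78%, the lower of the two numbers so far. Compound 3 `COc1ccccc1/C=C/C(=O)/C=C/c1ccc(OCc2cn(CCOc3cc(=O)oc4ccccc34)nn2)c(OC)c1` has not yet been measured and differs from compound 2 at one place: 2-methoxyphenyl in place of furan-2-yl on a double-bonded chain carbon bound to a double-bonded chain carbon. Among the measured compounds shown here, only one measured step bears on this change: a number 21 percentage points lower from compound 1 to compound 2 (beyond the scatter), with furan-2-yl replacing 3,4,5-trimethoxyphenyl at the same place. Compound 3 again carries a six-membered aromatic ring of carbon only there, so a modest rise is expected, though a single step is thin evidence. The estimated change is a number 9 percentage points higher from compound 2 to compound 3 (within the scatter). Compound 3 is expected at 87%, within an estimated range of 70% to 100%.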

Compound 3, percent growth inhibition at one concentration: 75%
Compound 3: the middle estimate sits 12 percentage points above what was measured, within the range that was stated.
By their numbers in this assay, from the lowest: compounds 3 and 2 (each within the scatter of the next); then compound 1.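

In this assay, a six-membered aromatic ring of carbon only does not by itself separate a group from furan-2-yl at this place: 2-methoxyphenyl gives a number 3 percentage points lower from compound 2 to compound 3 (within the scatter). The higher number of compound 1 therefore belongs to 3,4,5-trimethoxyphenyl specifically among these groups, as the change to 2-methoxyphenyl shows with a number 24 percentage points lower from compound 1 to compound 3 (beyond the scatter). No measurement offered here explains this difference.

The compounds shown leave open whether the number of methoxy groups or their places on the ring matters, since these two groups differ in both. They also leave open how an unsubstituted phenyl or a ring bearing an amine would behave at this place.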